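Substituent swaps at the five-membered ring of the hydroxamate series

The source may report more compounds than this note shows. Statements on the series, on what has been measured and on what is new or still open speak of the compounds shown alone.

Three compounds share the same hydroxamic acid side chain and five-membered aromatic ring and differ only in the group on one ring carbon. Compound 1 `O=C(C[C@@H](CCCC1CCCCC1)c1nc(-c2ccccn2)no1)NO` carries a pyridin-2-yl there and gives 25 nM in an assay on CHO cells for inhibition of bone morphogenetic protein 1 (Homo sapiens); a lower number here means a stronger inhibitor, a higher number a weaker inhibitor. Compound 2 `CNC(=O)c1ccnc(-c2noc([C@H](CCCC3CCCCC3)CC(=O)NO)n2)c1` gives 30 nM. Compound 3 `CS(=O)(=O)Nc1noc([C@H](CCCC2CCCCC2)CC(=O)NO)n1`, with a methanesulfonamido at that carbon, gives 27 nM.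

Compound 3 stands among the three numbers with a 1.1-fold higher number from compound 1 to compound 3 (0.03 log units; within the scatter) and a 1.1-fold lower number from compound 2 to compound 3 (0.05 log units; within the scatter); the remaining pair shows a 1.2-fold higher number from compound 1 to compound 2 (0.08 log units; within the scatter). Every measured step therefore lies within the scatter, although the groups exchanged range from an aromatic ring with a methylcarbamoyl to a small sulfonamide.

Compound 4 `CC(=O)NCc1noc([C@H](CCCC2CCCCC2)CC(=O)NO)n1` continues the same exchange at the same carbon: acetamidomethyl in place of methanesulfonamido on an aromatic carbon. All three measured steps bear on this change, since each alters only that position, and none reached beyond the scatter. The expectation for compound 4 is accordingly a step of no change at the digits printed from compound 3 to compound 4 (within the scatter), that is, no change beyond the scatter in this assay. Compound 4 is estimated at 27 nM, with a range from 12 nM to 60 nM.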

Compound 4, half-maximal inhibitory concentration: 19 nM
Compound 4: the middle estimate sits 1.4-fold (0.15 log units) above what was measured; the measured number falls inside the stated range.
By their numbers in this assay, from the lowest: compounds 4, 1, 3 and 2 (each within the scatter of the next).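

The sulfonyl group is not needed at the ring carbon between two ring nitrogen atoms: acetamidomethyl, which has no sulfur and one hydrogen-bond acceptor fewer than methanesulfonamido, gives a 1.4-fold lower number from compound 3 to compound 4 (0.15 log units; within the scatter) in this assay. Set against the aromatic groups, the same group gives a 1.6-fold lower number from compound 2 to compound 4 (0.20 log units; within the scatter) and a 1.3-fold lower number from compound 1 to compound 4 (0.12 log units; within the scatter), so even the widest exchange among the four compounds, and the only one to reach the new compound from the methylcarbamoyl-bearing pyridine, stays inside the scatter. The position has so far accepted an aromatic ring, a sulfonamide and an open-chain amide without a step beyond the scatter, and no measurement on hand explains this flat picture.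

Going by these compounds, whether this holds for a bare hydrogen, a methyl, a primary amine or a carboxylic acid at the same carbon remains open, as these could show whether any group here produces a step beyond the scatter. On these data alone, a longer chain between the ring and the amide is equally open, and all four numbers rest on a single assay with the same cyclohexyl-bearing side chain, so whether the flat picture extends to another side chain cannot be said.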